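The compounds below may be only part of what the source reports. "The series", "measured", "known", "first", "only" and "open" are said of these compounds alone.

Measured so far in an assay on HEK293 cells for displacement of a labelled ligand from 5-hydroxytryptamine receptor 7 (Homo sapiens); on this read-out lower numbers stand for stronger inhibition and higher numbers for weaker inhibition:
compound 1 `O=C1c2ccccc2S(=O)(=O)N1CCCCCN1CCN(c2ccccn2)CC1` — 179 nM
compound 2 `O=C1c2ccccc2S(=O)(=O)N1CCCCN1CCN(c2cccc(Cl)c2Cl)CC1` — 372 nM

Compound 1 stands lowest of the two numbers, and compound 2 gives 372 nM in this assay, a gap beyond the usual scatter. Going by the values given here, the two differ in more than one place, so no single step between them can be drawn; only their two values are known. Compound 3 `O=C1c2ccccc2S(=O)(=O)N1CCCCCN1CCN(c2cccc3ccccc23)CC1` has not yet been measured in this assay. It differs from compound 1 in one place: naphthalen-1-yl in place of pyridin-2-yl on an amine nitrogen in a ring. Nothing measured here shows how such a change plays out on this core, so the expectation rests on compound 1 alone, with its value of 179 nM as the anchor. The expected step is a 3.6-fold lower number from compound 1 to compound 3 (0.55 log units; beyond the scatter), a move to a lower number beyond the scatter. Compound 3 is accordingly estimated at 50 nM, within a range from 15 nM to 200 nM.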

Compound 3, inhibition constant: 36 nM
Beside the measured number, compound 3's estimate is 1.4-fold (0.14 log units) above it; the range from low to high includes it.
By their numbers in this assay, from the lowest: compound 3; then compound 1; then compound 2.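

Going by these compounds alone, on the amine nitrogen in the ring, naphthalen-1-yl in place of pyridin-2-yl gives, in this assay, a 5.0-fold lower number from compound 1 to compound 3 (0.70 log units; beyond the scatter), the first comparison here in which only one place changes. It shows that the number responds to the group at this position on the core of compound 1: two six-membered aromatic rings of carbon only, with no hydrogen-bond acceptor, replace one six-membered aromatic ring that holds a nitrogen. No measurement at hand explains the step.

Going by these compounds, whether the step follows from the added ring or from the loss of the ring nitrogen stays open, and a plain phenyl group or a quinolin-8-yl group at the same position could separate the two. On these data alone, it is also open whether naphthalen-1-yl would give a similar step on a shorter chain.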